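Sulfonamide series at the assay ceiling

A few compounds are considered here, and "the series" means these few. Any claim that something is new, unique, unknown or untested is made for them only; others in the source may bear on it.

Compound 3 `O=S(=O)(Nc1ccc2oc(-c3ccccc3)nc2c1)c1ccc(O)cc1` carries a 4-hydroxyphenyl on the sulfonyl sulfur. In an assay on isolated protein for inhibition of malate dehydrogenase, mitochondrial (Sus scrofa), with stated times of 45 min and 30 min (a higher number here means a weaker inhibitor, a lower number a stronger inhibitor), compound 3 returns only the limit > 63000 nM. The same holds for compound 1 `O=S(=O)(Nc1ccc2oc(-c3ccccc3)nc2c1)c1cccc(C(F)(F)F)c1`, for which this assay gives the limit > 63000 nM. Compound 2 `Cc1cccc(S(=O)(=O)Nc2ccc3oc(-c4ccccc4)nc3c2)c1` likewise reaches only the limit > 63000 nM. The steps a step that the two limits leave unreadable from compound 1 to compound 2 and a step that the two limits leave unreadable from compound 2 to compound 3 are therefore not readable, and the whole set rests on (the limit of > 63000 nM in this assay, at which 3 of the 3 values shown sit). Compound 4 `O=S(=O)(Nc1ccc2oc(-c3ccccc3)nc2c1)c1cccc(F)c1` differs from compound 3 as follows: 3-fluorophenyl in place of 4-hydroxyphenyl on a sulfonyl sulfur. Among the compounds with values here, no measured step speaks for a readable change; the expectation is the step that the limit leaves unreadable from compound 3 to compound 4, beyond the scatter in no direction. Compound 4 is therefore expected to give 80000 nM, with a range from 30000 nM to 300000 nM, and most likely only a limit again.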

Compound 4, half-maximal inhibitory concentration: > 63000 nM
Compound 4 ended at the assay's limit; the forecaster's own chance of this, stated with the estimate: 85%; the middle value lies beyond the limit too.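

Compound 4 adds no readable step against compound 1, compound 2 or compound 3, since all remain limits: the limit of > 63000 nM in this assay, at which 4 of the 4 values shown sit. As far as these compounds go, how these four compounds rank, and whether any of them inhibits the enzyme at all, stays open.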